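Swapping fluorine for bromine on the triazole-bound phenyl

The source may report more compounds than this note shows. Statements on the series, on what has been measured and on what is new or still open speak of the compounds shown alone.

Compound 2 `C/C(=C\CC/C(C)=C/CC[C@@H]1[C@@]2(C)CCC(=O)C(C)(C)[C@H]2CC[C@@]1(C)O)CC/C=C(\C)C(=O)OCc1cn(-c2ccccc2F)nn1` in an ADME assay on L132 cells (Homo sapiens) for cytotoxicity, read by MTT assay, with a stated time of 48 h (a lower number here means a stronger inhibitor, a higher number a weaker inhibitor), reaches only a limit of the assay, > 150000 nM. Compound 1 `C/C(=C\CC/C(C)=C/CC[C@@H]1[C@@]2(C)CCC(=O)C(C)(C)[C@H]2CC[C@@]1(C)O)CC/C=C(\C)C(=O)OCc1cn(-c2cccc(Cl)c2)nn1` in this assay gives 94200 nM. Within the data shown here, the single measured step, an at least 1.5-fold higher number from compound 1 to compound 2 (0.20 log units; that floor lies within the scatter), ends at that limit (the limit of > 150000 nM in this assay, at which 1 of the 2 values shown sits), so its true size is unknown. Compound 3 `C/C(=C\CC/C(C)=C/CC[C@@H]1[C@@]2(C)CCC(=O)C(C)(C)[C@H]2CC[C@@]1(C)O)CC/C=C(\C)C(=O)OCc1cn(-c2cccc(Br)c2)nn1` carries the change (3-bromophenyl in place of 2-fluorophenyl on an aromatic nitrogen), which again places a halogen on the phenyl ring, as compound 1 does. Because compound 1 gives 94200 nM, compound 3 is expected to land near that number. The expected step is an at least 1.5-fold lower number from compound 2 to compound 3 (0.17 log units; that floor lies within the scatter). The estimate for compound 3 is 100000 nM, between 45000 nM and 220000 nM.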

Compound 3, half-maximal inhibitory concentration: > 150000 nM
Compound 3 ended at the assay's limit; the forecaster's own chance of this, stated with the estimate: 30%; middle value at least 1.5-fold (0.17 log units) from the limit.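

Compound 3 stands only at a limit of the assay, not at a number. With bromo in place of chloro on the phenyl ring, the measured change is an at least 1.5-fold higher number from compound 1 to compound 3 (0.20 log units; that floor lies within the scatter), so a larger effect remains possible but is not shown. The step between compound 2 and compound 3 cannot be read, because both stand at the same ceiling: the limit of > 150000 nM in this assay, at which 2 of the 3 values shown sit.

Still open, as far as these compounds go, is how far compound 2 and compound 3 lie past that limit. Also open, from the compounds shown here alone, is whether an amine or a carboxylic acid on this phenyl ring would give a readable number in this assay.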